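The source may hold more compounds than are shown below. What is called first, only, known or untested is meant among the compounds shown, and "the series" means these compounds.

Measured so far:
Compound 1, `Nc1nccc(-c2cc3c4c(n[nH]c4c2)Nc2ccncc2O3)n1`: 10000 nM
Compound 2, `Nc1cc(-c2ccc3c(N)n[nH]c3c2)nc(N)n1`: 58000 nM
Compound 3, `Nc1nccc(-c2cc(OCc3ccccc3)c3c(N)n[nH]c3c2)n1`: 85000 nM

These three compounds were tested in a physicochemical assay for solubility, read by LC-MS, in phosphate buffer, measured as kinetic solubility, with a stated time of 24 h, at 25 degrees C, at pH 7.4; a lower number here means a less soluble compound, a higher number a more soluble compound. Compound 3 sits at the upper end of the three numbers: its gap to compound 2 is within the usual scatter of such measurements, so the two cannot be told apart, while its gap to compound 1 is beyond the scatter, so compound 3 is clearly more soluble than compound 1.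

Compound 4, `CCOc1cc(-c2ccnc(N)n2)cc2[nH]nc(N)c12`, has not yet been measured. It differs from compound 3 in one place: methyl in place of phenyl on a saturated chain carbon bound to an oxygen on an aromatic ring. For the measured compounds named here, no measured pair shows this same change, so no measured step can be leaned on; the expectation below rests on compound 3 alone.

For compound 4 a rise in this assay is expected, of a size that goes beyond the scatter but stays modest, the expected step being a 2.4-fold higher number from compound 3 to compound 4 (0.37 log units; beyond the scatter). Compound 4 is therefore estimated at 200000 nM, within a range from 80000 nM to 500000 nM.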

Compound 4, solubility: 861000 nM
Compound 4: the middle estimate sits 4.3-fold (0.63 log units) below what was measured; the measured number lies above the stated range.
By their numbers in this assay, from the lowest: compound 1; then compounds 2 and 3 (each within the scatter of the next); then compound 4.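

In this assay, putting ethoxy in place of benzyloxy gives a 10-fold higher number from compound 3 to compound 4 (1.01 log units; beyond the scatter), a large step and well beyond the scatter. For the compounds shown here, no two earlier compounds differed in only one place, so this is the first direct sign that the group on this saturated chain carbon, bound to an oxygen on an aromatic ring, can strongly shift the reading. Nothing available explains why the step is this large.

This single pair changes the size of the group and removes its aromatic ring at once, so it cannot show which of the two matters, or whether the same step would appear on another core. It also leaves open where a longer chain, such as propyl in place of the methyl, would fall, and what an amine or a carboxylic acid at this place would do.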